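A few compounds are considered here, and "the series" means these few. Any claim that something is new, unique, unknown or untested is made for them only; others in the source may bear on it.

Measured compounds in a functional assay on U-251 cells (Homo sapiens) for inhibition, read by sulforhodamine B assay, with a stated time of 48 h; on this read-out lower numbers stand for stronger inhibition of growth and higher numbers for weaker inhibition of growth:
Compound 1, `C=C(C)[C@@H]1CC=C(Cn2cc(COc3ccc(C4NC(=O)NC(C)=C4C(=O)OCC)cc3)nn2)CC1`, gives 12400 nM.
Compound 2, `C=C(C)[C@@H]1CC=C(Cn2cc(COc3ccc(C4NC(=O)NC(C)=C4C(=O)OCC)cc3OC)nn2)CC1`, gives 11300 nM.
Compound 3, `C=C(C)[C@@H]1CC=C(Cn2cc(COc3cccc(C4NC(=O)NC5=C4C(=O)CC(C)(C)C5)c3)nn2)CC1`, gives 26000 nM.

Compound 1 and compound 2 share one core and differ in a single place: methoxy in place of hydrogen on an aromatic carbon. That change made a 1.1-fold lower number from compound 1 to compound 2 (0.04 log units; within the scatter), a step within the usual scatter of repeated measurements, so the two values cannot be told apart. Compound 3 carries a different core; how its core differs from that of compound 1 is not broken down here. Its value lies beyond the scatter from both compound 1 and compound 2.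

Compound 4, `C=C(C)[C@@H]1CC=C(Cn2cc(COc3cc(C4NC(=O)NC5=C4C(=O)CC(C)(C)C5)ccc3OC)nn2)CC1`, has not yet been measured in this assay. It is derived from compound 3 by methoxy in place of hydrogen on an aromatic carbon. Within the data shown here, this is the same kind of change as the one from compound 1 to compound 2, but not the same: in compound 2 the methoxy sits ortho to a large group and meta to a large group, whereas in compound 4 it sits ortho to a large group and para to a large group. Because a 1.1-fold lower number from compound 1 to compound 2 (0.04 log units; within the scatter) stayed within the scatter, the step for compound 4 is expected to be small as well, a 1.1-fold lower number from compound 3 to compound 4 (0.03 log units; within the scatter), though the different surroundings and the different core leave room for a larger move. Compound 4 is therefore expected to give about 24000 nM in this assay, most likely between 11000 nM and 55000 nM.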

Compound 4, concentration for total growth inhibition: 8280 nM
Beside the measured number, compound 4's estimate is 2.9-fold (0.46 log units) above it, and the stated range ends above it.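

In this assay, methoxy in place of hydrogen gave a 3.1-fold lower number from compound 3 to compound 4 (0.50 log units; beyond the scatter), and this step differs from the one seen earlier for the same change on the other core: the same change on two cores in this assay, a 1.1-fold lower number (0.04 log units; within the scatter) from compound 1 to compound 2 and a 3.1-fold lower number (0.50 log units; beyond the scatter) from compound 3 to compound 4, 2.9-fold (0.46 log units) apart, beyond the scatter of two such steps

So in this series, the size of the step on the core of compound 1 did not carry over to the core of compound 3. This pair of steps does not show why: the methoxy in compound 4 sits ortho to a large group and para to a large group, its surroundings differ from those in compound 2, and a single step on each core cannot separate the effect of the core from the effect of the placement.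

The compounds shown leave open whether the methoxy placement of compound 2 would give a similar step on the core of compound 3. They also leave open whether a hydroxyl, an ethoxy or an amine at the methoxy position of compound 4 would give a step of similar size.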